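Trimethoxy to dimethoxy: one methoxy removed from compound 2

The source may report more compounds than this note shows. Statements on the series, on what has been measured and on what is new or still open speak of the compounds shown alone.

Measured so far:
compound 1 `COc1cc(/C=N/Cc2cccnc2)ccc1O`: 100 mg/kg
compound 2 `COc1cc(/C=N/Cc2cccnc2)cc(OC)c1OC`: 100 mg/kg

Both values come from a functional assay on the whole organism (strain Swiss albino) with Mus musculus as the target, in the maximal electroshock model, with a stated time of 0.5 h; a higher number here means that more compound is needed for the effect, a lower number that less compound is needed. Going by the values given here, compound 2 stands level with compound 1 at the digits given; the two values lie within the scatter of one another, so nothing can be said about order between them, and no step between measured compounds is available for this series.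

Compound 3 `COc1ccc(/C=N/Cc2cccnc2)cc1OC` is the next member. It differs from compound 2 by hydrogen in place of methoxy on an aromatic carbon. The two measured compounds differ from each other by more than one group, so their common value gives no direct reading of what the loss of a single methoxy does here.

Among the compounds with values here, with no step to lean on, the expectation is that the change from compound 2 to compound 3 stays within the scatter; the expected step is no change at the digits printed from compound 2 to compound 3 (within the scatter), that is, none beyond the scatter in either direction. Compound 3 is therefore estimated at 100 mg/kg in this assay, with a range from 50 mg/kg to 200 mg/kg.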

Compound 3, minimum effective dose: 300 mg/kg
Compound 3: middle estimate off by 3.0-fold (0.48 log units), on the low side; the whole stated range lies below it.
By their numbers in this assay, from the lowest: compounds 1 and 2 (each within the scatter of the next); then compound 3.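

In this assay, the methoxy ortho to a methoxy group and meta to a group of 9 heavy atoms now has a reading of its own: hydrogen in its place gives a 3.0-fold higher number from compound 2 to compound 3 (0.48 log units; beyond the scatter), so at this position the change from methoxy to hydrogen is not silent, and more compound is needed without that group. A second single change ends at the same compound, since methyl in place of hydrogen on the ring oxygen gives a 3.0-fold higher number from compound 1 to compound 3 (0.48 log units; beyond the scatter), which means that compound 3 stands apart from two neighbours that each differ from it in one place, while the level values of compound 1 and compound 2 gave no hint of any such separation. No measurement at hand accounts for either step, so the reason for them stays unexplained.

As far as these compounds go, whether the gain at the first position needs methoxy itself or would also appear with a fluorine atom, an ethoxy group or an amine there remains open. Also open, from the compounds shown here alone, is whether a longer chain on the ring oxygen of compound 1 would stay level with compound 1 or move towards compound 3.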